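Pyrrolylmethylene thiazolidinone anilides: step to the 4-ethylphenyl analogue

The source may hold more compounds than are shown below. What is called first, only, known or untested is meant among the compounds shown, and "the series" means these compounds.

Two members of the series have numbers in a functional assay on JAR cells (Homo sapiens) for inhibition, read by MTT assay, with a stated time of 72 h, tested at 10 uM; a lower number here means less inhibition, a higher number more inhibition at the concentration tested (going by the name of the read-out). Compound 1 `CCOC(=O)C1=C(Nc2ccc(Br)cc2)S/C(=C\c2ccc[nH]2)C1=O` gives 41.5% in this assay. For the measured compounds named here, compound 2 `CCOC(=O)C1=C(Nc2cccc([N+](=O)[O-])c2)S/C(=C\c2ccc[nH]2)C1=O` gives 57.4% in this assay, the highest of the two numbers, with compound 1 the nearest at a lower number; the one measured step, a number 15.9 percentage points higher from compound 1 to compound 2 (beyond the scatter), is the only change of the aryl group on the amine nitrogen seen so far.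

Compound 3 `CCOC(=O)C1=C(Nc2ccc(CC)cc2)S/C(=C\c2ccc[nH]2)C1=O` is not yet measured. It differs from compound 2 as follows: 4-ethylphenyl in place of 3-nitrophenyl on an amine nitrogen. Going by the values given here, the only step that bears on this is the replacement on the same amine nitrogen, a number 15.9 percentage points higher from compound 1 to compound 2 (beyond the scatter), which moved the number by a modest amount beyond the scatter. Nothing in the series shows how a 4-ethylphenyl group on the amine nitrogen behaves, so the expectation rests on the direction of that single step: leaving 3-nitrophenyl is expected to undo the gain seen on entering it. Compound 3 is therefore expected to give 42% in this assay, within 25% to 60%, the expected step being a number 15.4 percentage points lower from compound 2 to compound 3 (beyond the scatter).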

Compound 3, a percentage reported as inhibition, at one concentration (the size of the read-out at that concentration, not a potency): < 10%
Compound 3 gave a limit, no number; the forecaster's own chance of this, stated with the estimate: 2%; at least 32 percentage points between middle value and limit.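

In this assay compound 3 stands at a limit of the assay, not at a number: the limit of < 10% in this assay, at which 1 of the 3 values shown sits.

The aryl group on the amine nitrogen therefore matters more than the earlier modest step suggested, since 4-ethylphenyl in place of 3-nitrophenyl gives a number at least 47.4 percentage points lower from compound 2 to compound 3 (beyond the scatter), a large step. Ethyl in place of bromo on an aromatic carbon gives a number at least 31.5 percentage points lower from compound 1 to compound 3 (beyond the scatter), also large, so 4-bromophenyl and 4-ethylphenyl are not interchangeable at this position, and the 3-nitrophenyl group is not needed for a measurable number, as compound 1 shows.

The compounds shown leave open whether the loss belongs to ethyl alone or extends to other carbon substituents on the phenyl ring, such as a methyl group or a longer chain. They also leave open how a group such as an amine or a carboxylic acid on that ring would read in this assay, and whether the higher number of compound 2 comes from the nitro group itself or from its place on the ring.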